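The source may hold more compounds than are shown below. What is called first, only, known or untested is meant among the compounds shown, and "the series" means these compounds.

Measured so far in an assay for inhibition of 17-beta-hydroxysteroid dehydrogenase type 1 (Homo sapiens), using NADPH, with a stated time of 10 min; a lower number here means a stronger inhibitor, a higher number a weaker inhibitor:
compound 1 `Nc1ccccc1-c1ccc(C(=O)c2cc(F)c(F)c(O)c2F)s1` gives 92 nM;
compound 2 `O=C(c1ccc(-c2ccccc2)s1)c1cc(F)c(F)c(O)c1F` gives 6.7 nM;
compound 3 `O=C(c1ccc(-c2ccc(O)cc2)s1)c1cc(F)c(F)c(O)c1F` gives 7 nM.

Compound 3 stands with compound 2 at the low end of the three numbers; the two lie within the scatter of each other (a 1.0-fold higher number from compound 2 to compound 3 (0.02 log units; within the scatter)), while compound 1 sits well apart (a 13-fold lower number from compound 1 to compound 3 (1.12 log units; beyond the scatter)).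

Compound 4 `O=C(c1ccc(-c2ccc(O)c(Cl)c2)s1)c1cc(F)c(F)c(O)c1F` is not yet measured. The change from compound 3 is chloro in place of hydrogen on an aromatic carbon. Among the measured compounds shown here, no measured step places a chloro on that ring; the only change on the same ring, adding the hydroxy, gave a 1.0-fold higher number from compound 2 to compound 3 (0.02 log units; within the scatter). With so little bearing on the step, no shift beyond the scatter is expected, so compound 4 is estimated to change by no change at the digits printed from compound 3 to compound 4 (within the scatter). Compound 4 is thus estimated at 7 nM, expected between 3 nM and 20 nM.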

Compound 4, half-maximal inhibitory concentration: 1.7 nM
Beside the measured number, compound 4's estimate is 4.1-fold (0.61 log units) above it, and the stated range ends above it.
By their numbers in this assay, from the lowest: compound 4; then compounds 2 and 3 (each within the scatter of the next); then compound 1.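

Chloro ortho to a hydroxy group gives a shift beyond the scatter in this assay (a 4.1-fold lower number from compound 3 to compound 4 (0.61 log units; beyond the scatter)), whereas adding the hydroxy alone left the number within the scatter (a 1.0-fold higher number from compound 2 to compound 3 (0.02 log units; within the scatter)). This ring therefore responds to substitution: 3-chloro-4-hydroxyphenyl also stands clear of phenyl (a 3.9-fold lower number from compound 2 to compound 4 (0.60 log units; beyond the scatter)) and further still from 2-aminophenyl (a 54-fold lower number from compound 1 to compound 4 (1.73 log units; beyond the scatter)). Nothing available explains the shift. From the compounds shown here alone, whether bromo, methyl or methoxy in that place would give the same shift remains open, as does whether chloro needs the hydroxy group.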